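Cyclohexyl in place of 4-chlorophenyl: notes on compound 4

This account rests on a few compounds, and the source may have more. Where it says the series, first, only, none or still open, it means among the compounds named here.

In a functional assay on HepG2 cells (Homo sapiens) for antiproliferative activity, read by MTT assay, with a stated time of 72 h (a lower number here means a stronger inhibitor, a higher number a weaker inhibitor), compound 1 `COc1ncc(-c2ccc3c(c2)N(c2ccccc2)C(=O)CO3)cc1NS(=O)(=O)c1ccc(F)cc1` gives 14000 nM as its value, and compound 2 `O=C1COc2ccc(-c3cccc(NS(=O)(=O)c4ccc(F)cc4)c3)cc2N1c1ccc(Cl)cc1` gives 27800 nM as its value, so the two lie within the scatter of each other. Compound 3 `O=C1COc2ccc(-c3cnc(Cl)c(NS(=O)(=O)c4ccc(F)cc4)c3)cc2N1C1CC1` gives 8510 nM as its value, a lower number than compound 2 and beyond the scatter from it. Within the data shown here, compound 1 and compound 3 each differ from compound 2 in more than one place, so no single-change step has been measured.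

Compound 4 `O=C1COc2ccc(-c3cccc(NS(=O)(=O)c4ccc(F)cc4)c3)cc2N1C1CCCCC1`, not yet measured, differs from compound 2 by one change cyclohexyl in place of 4-chlorophenyl on an amide-type nitrogen in a ring with cyclohexyl in place of 4-chlorophenyl on an amide-type nitrogen in a ring. Among the measured compounds shown here, with no measured pair isolating this change, no shift beyond the scatter is expected in this assay and only a slight drift to a lower number is expected. The estimated step is a 1.4-fold lower number from compound 2 to compound 4 (0.14 log units; within the scatter) and it is expected to stay within the scatter. In this assay the estimate for compound 4 is 20000 nM within an expected range of 8000 nM to 50000 nM as the likely outcome.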

Compound 4, half-maximal inhibitory concentration: 35900 nM
Compound 4: middle estimate off by 1.8-fold (0.25 log units), on the low side, within the range that was stated.
By their numbers in this assay, from the lowest: compounds 3, 1, 2 and 4 (each within the scatter of the next, the first and the last beyond it).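

In this assay, among these compounds, the first single-change step is a 1.3-fold higher number from compound 2 to compound 4 (0.11 log units; within the scatter) and it lies within the scatter, so on the amide-type nitrogen in a ring, cyclohexyl in place of 4-chlorophenyl leaves the number unresolved from that of compound 2. With the rest of the structure shared, this pair does not tell an aromatic ring of carbon only from a non-aromatic ring of carbon only at this position. No measurement bears on why the two groups read alike.

Going by these compounds, whether an amine, a carboxylic acid or a longer chain such as n-butyl on this nitrogen would give a step beyond the scatter remains open. On these data alone, compound 3 carries cyclopropyl there but differs from compound 2 in more than one place, so the effect of a smaller ring at this position also remains open.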